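From compound 3 to compound 4

A few compounds are considered here, and "the series" means these few. Any claim that something is new, unique, unknown or untested is made for them only; others in the source may bear on it.

Compound 1, `CNc1[nH]c(=O)n(O)c(=O)c1C(=O)NCc1ccccc1`, in an ADME assay on a cell-free system (plasma, Mus musculus) for metabolic stability; a higher number here means that the compound lasts longer, a lower number that the compound disappears faster: > 24 h, a limit of the assay.
Compound 2, `CCNc1[nH]c(=O)n(O)c(=O)c1C(=O)NCc1ccc(F)cc1`, in this assay: > 24 h, a limit of the assay.
Compound 3, `CCNc1[nH]c(=O)n(O)c(=O)c1C(=O)NCc1cccc(Cl)c1F`, in this assay: > 24 h, a limit of the assay.

Compound 3 therefore stands only at a limit in this assay, and the other two values shown are limits as well; (the limit of > 24 h in this assay, at which 3 of the 3 values shown sit). Going by the values given here, the one step between measured compounds that differ in one place, a step that the two limits leave unreadable from compound 2 to compound 3, cannot be read for size or direction because both ends are limits. Compound 4, `CCNc1[nH]c(=O)n(O)c(=O)c1C(=O)NCc1ccc(C)c(F)c1`, has not yet been measured in this assay. It differs from compound 3 in one place: 3-fluoro-4-methylphenyl in place of 3-chloro-2-fluorophenyl on a saturated chain carbon bound to an amide-type nitrogen. The measured steps give no readable guide to the size of this change, and the three compounds shown give only limits, so no step beyond the scatter can be argued for in either direction. The step from compound 3 to compound 4 that this account expects, a step that the limit leaves unreadable from compound 3 to compound 4, is accordingly none beyond the scatter. Compound 4 is expected to give 30 h in this assay, with a range from 12 h to 70 h, most likely again reported as a limit.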

Compound 4, half-life in the Mus musculus assay: > 24 h
Compound 4 gave a limit, no number; the forecaster's own chance of this, stated with the estimate: 80%; the middle value does not contradict the limit.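

No new step can be read in the Mus musculus assay among compound 2, compound 3 and compound 4, whose values are all limits of the assay: the limit of > 24 h in the Mus musculus assay, at which 4 of the 4 values shown sit.

In a physicochemical assay for solubility (on this read-out lower numbers stand for lower solubility and higher numbers for higher solubility), compound 3 gives 11000 nM. In the physicochemical assay compound 4 gives 81000 nM. In the physicochemical assay this is a 7.4-fold higher number from compound 3 to compound 4 (0.87 log units; beyond the scatter).

The compounds shown leave open how long any of them actually lasts in the Mus musculus assay, and whether these changes of group alter that half-life at all.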